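Swapping a difluorophenyl for a benzothiophene on a sulfonamide

This account rests on a few compounds, and the source may have more. Where it says the series, first, only, none or still open, it means among the compounds named here.

Of the compounds shown here, three have been measured in a physicochemical assay for lipophilicity, at pH 7.4; on this read-out lower numbers stand for lower lipophilicity and higher numbers for higher lipophilicity. Compound 1 `CCc1ccc(N(CC(C)C)S(=O)(=O)c2ccc(OCC3CCOCC3)c3c2CCC3=O)cc1` gives 4.44, compound 2 `CCS(=O)(=O)c1ccc(CNS(=O)(=O)c2ccc3c(c2)C(=O)CC(C2CCOCC2)O3)nc1` gives 0.32, and compound 3 `CC(C)CN(c1ccc(F)cc1F)S(=O)(=O)c1ccc2c(c1)C(=O)CC(C1CCOCC1)O2` gives 3.62. Compound 3 therefore stands second highest of the three: compound 1 lies above it by a gap beyond the scatter, and compound 2 lies far below it, also beyond the scatter. Compound 4 `CC(C)CN(c1cc2ccccc2s1)S(=O)(=O)c1ccc2c(c1)C(=O)CC(C1CCOCC1)O2` differs from compound 3 in one place: 1-benzothiophen-2-yl in place of 2,4-difluorophenyl on a sulfonamide nitrogen. Among the measured compounds shown here, no measured pair shows this exact change, so only the structures guide the expectation. The step from compound 3 to compound 4 in this assay is expected to be an increase, estimated at a number 0.68 log units higher from compound 3 to compound 4 (beyond the scatter). Compound 4 is accordingly estimated at 4.3, within a range from 3.7 to 4.9.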

Compound 4, distribution coefficient: 4.01
Compound 4: middle estimate off by 0.29 log units, on the high side; low and high end bracket the measured number.
By their numbers in this assay, from the lowest: compound 2; then compound 3; then compound 4; then compound 1.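

On a sulfonamide nitrogen, 1-benzothiophen-2-yl in place of 2,4-difluorophenyl gives in this assay a modest step, a number 0.39 log units higher from compound 3 to compound 4 (beyond the scatter). This is the first pair shown that differs in one place, so the effect of changing this group on the read-out can now be seen directly rather than inferred across compounds that differ in several places. Nothing available explains the size or direction of this step. Still open, going by these compounds, is how a cyclohexyl group or a pyridine ring at this position would compare, and whether the same swap would give a similar step on a different core.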